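A few compounds are considered here, and "the series" means these few. Any claim that something is new, unique, unknown or untested is made for them only; others in the source may bear on it.

Within the data shown here, in an ADME assay on L929 cells (Mus musculus) for cytotoxicity, read by resazurin assay, with a stated time of 48 h (on this read-out lower numbers stand for higher toxicity in this test and higher numbers for lower toxicity in this test), compound 1 `C#CCn1c2ccc([N+](=O)[O-])cc2c(=O)n1Cc1ccccc1` gives 195000 nM, the only plain number among the three measured compounds. Compound 2 `COC(=O)CCn1c2ccc([N+](=O)[O-])cc2c(=O)n1Cc1ccccc1` reaches only the limit of > 256000 nM in this assay. Compound 3 `O=C(O)CCn1c2ccc([N+](=O)[O-])cc2c(=O)n1Cc1ccccc1` likewise stops at the limit of > 256000 nM in this assay. The resulting steps are an at least 1.3-fold higher number from compound 1 to compound 2 (0.11 log units; that floor lies within the scatter) and an at least 1.3-fold higher number from compound 1 to compound 3 (0.11 log units; that floor lies within the scatter), so both replacements of the ethynyl group moved the read-out to the limit of > 256000 nM in this assay, at which 2 of the 3 values shown sit.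

Compound 4 `Cc1ccc(S(=O)(=O)n2c3ccc([N+](=O)[O-])cc3c(=O)n2Cc2ccccc2)cc1` differs from compound 1 by (4-methylphenyl)sulfonyl in place of propargyl on an aromatic nitrogen. Among the measured compounds shown here, no measured step exchanges a propargyl for a sulfonyl group, so the measured steps give little guidance. Compound 4 is expected to give about 180000 nM, within 80000 nM to 300000 nM. The expected step is a 1.1-fold lower number from compound 1 to compound 4 (0.03 log units; within the scatter).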

Compound 4, concentration lethal to 50% of the cells: > 256000 nM
Compound 4 gave a limit, no number; the forecaster's own chance of this, stated with the estimate: 40%; at least 1.4-fold (0.15 log units) between middle value and limit.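

In this assay, compound 4 gives only a limit. Placing (4-methylphenyl)sulfonyl on this aromatic nitrogen gives an at least 1.3-fold higher number from compound 1 to compound 4 (0.11 log units; that floor lies within the scatter), so a much larger group with an aromatic ring, attached through sulfonyl and not through a saturated chain carbon, brings no lower number. The steps linking compound 4 to compounds 2 and 3 cannot be read, and the values now gather at one end: the limit of > 256000 nM in this assay, at which 3 of the 4 values shown sit.

As far as these compounds go, whether any group on this nitrogen can give a lower number than compound 1 stays open. An amine or a longer chain of plain carbon here remains untested in the compounds shown.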